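Moving the Nitro Group Around the Phenyl Ring

The source may hold more compounds than are shown below. What is called first, only, known or untested is meant among the compounds shown, and "the series" means these compounds.

Measured so far:
Compound 1 `Nc1nc(N)c2cc(CSC(=S)N3CCN(c4ccccc4)CC3)ccc2n1` gives 2950 nM in a functional assay on MCF7 cells (Homo sapiens) for antiproliferative activity, read by MTT assay, with a stated time of 72 h; on this read-out higher numbers stand for weaker inhibition and lower numbers for stronger inhibition.
Compound 2 `Nc1nc(N)c2cc(CSC(=S)N3CCN(c4ccc(O)cc4)CC3)ccc2n1` gives 5090 nM in this assay.
Compound 3 `Nc1nc(N)c2cc(CSC(=S)N3CCN(c4ccc([N+](=O)[O-])cc4)CC3)ccc2n1` gives 1470 nM in this assay.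

Compound 1 stands second highest of these three numbers; its nearest neighbour is compound 2, a 1.7-fold higher number from compound 1 to compound 2 (0.24 log units; within the scatter). Compound 4 `Nc1nc(N)c2cc(CSC(=S)N3CCN(c4ccccc4[N+](=O)[O-])CC3)ccc2n1` differs from compound 1 by nitro in place of hydrogen on an aromatic carbon, the phenyl becoming a 2-nitrophenyl. For the measured compounds named here, the only guide is the same group placed elsewhere on that ring: a 2.0-fold lower number from compound 1 to compound 3 (0.30 log units; within the scatter), and a 3.5-fold lower number from compound 2 to compound 3 (0.54 log units; beyond the scatter). Since the nitro step from compound 1 stayed within the scatter, no step beyond the scatter is expected here either, perhaps a slightly lower number. Compound 4 is therefore estimated at 2200 nM, within 900 nM to 5500 nM, an expected step of a 1.3-fold lower number from compound 1 to compound 4 (0.13 log units; within the scatter).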

Compound 4, half-maximal inhibitory concentration: 4350 nM
Compound 4: middle estimate off by 2.0-fold (0.30 log units), on the low side; the measured number falls inside the stated range.
By their numbers in this assay, from the lowest: compounds 3, 1, 4 and 2 (each within the scatter of the next, the first and the last beyond it).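

The place of the nitro on the phenyl ring counts: going from 4-nitrophenyl to 2-nitrophenyl gives a 3.0-fold higher number from compound 3 to compound 4 (0.47 log units; beyond the scatter) in this assay. As a 2-nitrophenyl, the nitro leaves the number within the scatter of the plain phenyl (a 1.5-fold higher number from compound 1 to compound 4 (0.17 log units; within the scatter)) and of the 4-hydroxyphenyl (a 1.2-fold lower number from compound 2 to compound 4 (0.07 log units; within the scatter)). Nothing given here explains why the two nitro compounds differ.

Still open, from the compounds shown here alone, is whether this dependence on place holds for other groups on the phenyl ring, such as an amine or a carboxylic acid.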